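The source may hold more compounds than are shown below. What is called first, only, known or untested is meant among the compounds shown, and "the series" means these compounds.

Three compounds share one core, a five-membered ring carrying a propanoyl group and two aryl rings, and differ only in the groups on those aryl rings. Compound 1 `CCC(=O)N1N=C(c2ccccc2)CC1c1ccc(F)cc1` is the reference; in an assay on isolated protein for inhibition of Amine oxidase [flavin-containing] A (Bos taurus) (a lower number here means a stronger inhibitor, a higher number a weaker inhibitor), compound 1 gives 7240 nM. Compound 2 `CCC(=O)N1N=C(c2ccccc2)CC1c1ccc(C)cc1` carries the change (methyl in place of fluoro on an aromatic carbon), and in this assay compound 2 gives 75900 nM, so that a 10-fold higher number from compound 1 to compound 2 (1.02 log units; beyond the scatter). Compound 3 `CCC(=O)N1N=C(c2ccc(OC)cc2)CC1c1ccc(F)cc1` instead carries the change (methoxy in place of hydrogen on an aromatic carbon), and in this assay compound 3 gives 1000 nM, which means a 7.2-fold lower number from compound 1 to compound 3 (0.86 log units; beyond the scatter); among the three numbers, this is the lowest.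

Compound 4 `CCC(=O)N1N=C(c2ccc(OC)cc2)CC1c1ccc(C)cc1` is not yet measured. It differs from compound 3 by methyl in place of fluoro on an aromatic carbon, the same change, at the same place, that separates compound 2 from compound 1, while the cores of compound 3 and compound 4 differ from that of compound 1 by the change just described. The expectation for compound 4 rests on the earlier step: because a 10-fold higher number from compound 1 to compound 2 (1.02 log units; beyond the scatter), a weakening of similar size is expected here, an 8.0-fold higher number from compound 3 to compound 4 (0.90 log units; beyond the scatter). Compound 4 is therefore estimated at 8000 nM, likely between 3000 nM and 25000 nM.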

Compound 4, half-maximal inhibitory concentration: 7240 nM
The estimate for compound 4 lay 1.1-fold (0.04 log units) above the measured number; low and high end bracket the measured number.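

In this assay, putting methyl in place of fluoro on the core that carries the methoxy gave a 7.2-fold higher number from compound 3 to compound 4 (0.86 log units; beyond the scatter), and this step matches the one seen on the core without the methoxy: the same change on two cores in this assay, a 10-fold higher number (1.02 log units; beyond the scatter) from compound 1 to compound 2 and a 7.2-fold higher number (0.86 log units; beyond the scatter) from compound 3 to compound 4, 1.4-fold (0.16 log units) apart, within the scatter of two such steps

Read the other way, adding the methoxy to the compound that carries the methyl gave a 10-fold lower number from compound 2 to compound 4 (1.02 log units; beyond the scatter), and this step also matches its earlier counterpart: the same change on two cores in this assay, a 7.2-fold lower number (0.86 log units; beyond the scatter) from compound 1 to compound 3 and a 10-fold lower number (1.02 log units; beyond the scatter) from compound 2 to compound 4, 1.4-fold (0.16 log units) apart, within the scatter of two such steps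

So within these four compounds each change keeps its size when carried to the other core, which means the two changes simply add up here, but this one set of four shows neither why that happens nor that it would hold for other changes or in other assays.

The compounds shown leave open whether such adding up continues with other groups, for example chloro in place of fluoro, or an amine in place of methoxy. They also leave open what a longer chain in place of the propanoyl group would do to these steps.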